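Removing One Group From Compound 1

The compounds below may be only part of what the source reports. "The series", "measured", "known", "first", "only" and "open" are said of these compounds alone.

Among the measured compounds shown here, in a functional assay on A549 cells (Homo sapiens) for antiproliferative activity, read by CCK-8 assay, with a stated time of 72 h (on this read-out higher numbers stand for weaker inhibition and lower numbers for stronger inhibition), compound 1 `C/C(=N\O)c1ccc(OCc2ccc(C(=O)NO)cc2)cc1` gives 8930 nM, the only actual number available so far. Compound 2 `Nc1ccccc1NC(=O)c1ccc(COc2ccc([N+](=O)[O-])cc2)cc1` reads > 32000 nM in this assay, and this is a limit of the assay, not a number. Compound 3 `O=C(NO)c1ccc(COc2ccccc2)cc1` is compound 1 with a single change: a hydrogen atom in place of a group of 4 heavy atoms (2 carbon, 1 nitrogen, 1 oxygen; no ring), on an aromatic carbon. The change sits on an aromatic carbon of a six-membered aromatic ring of carbon only, para to a large group. For the measured compounds named here, no pair of measured compounds shows what such a change does, so the estimate has only compound 1 to start from. The expected 1.3-fold higher number from compound 1 to compound 3 (0.13 log units; within the scatter) is small, leaning toward weaker inhibition, and it may well stay within the usual scatter. The estimated value in this assay for compound 3 is 12000 nM, with a likely range of 4000 nM to 32000 nM.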

Compound 3, half-maximal inhibitory concentration: 28000 nM
Estimate against measurement, compound 3: 2.3-fold (0.37 log units) below; the range from low to high includes it.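

In this assay, putting a hydrogen atom on the aromatic carbon in place of the group of 4 heavy atoms gives a 3.1-fold higher number from compound 1 to compound 3 (0.50 log units; beyond the scatter). Among the compounds shown here, this is the first comparison of two measured compounds that differ in one place, and it shows that this position is not indifferent: in this pair, the stronger inhibition goes with keeping the group. Little room remains for reading further weakening as a number, since compound 2 reads only as a limit of the assay: the limit of > 32000 nM in this assay, at which 1 of the 3 values shown sits.

This single pair cannot tell which atoms of the departed group matter, or whether its full size is needed. On these data alone, whether a methyl group, an amine or a carboxylic acid on the same aromatic carbon would hold, raise or lower the number remains open.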